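Extending the chain one more carbon beyond compound 3

This account rests on a few compounds, and the source may have more. Where it says the series, first, only, none or still open, it means among the compounds named here.

Compound 1 `N#C/N=C1\N(CCCCCCCOc2ccc(Cl)cc2)C(=O)CN1c1ccncc1`: in a functional assay on HA22T cells for cytotoxicity against HA22T cell line (Homo sapiens) (on this read-out higher numbers stand for weaker inhibition and lower numbers for stronger inhibition), compound 1 gives 3500 nM.
Compound 2 `N#C/N=C1\N(CCCCCOc2ccc(Cl)cc2)C(=O)C(c2ccccc2)N1c1ccncc1`: in this assay compound 2 gives 3590 nM.
Compound 3 `N#C/N=C1\N(CCCCCCOc2ccc(Cl)cc2)C(=O)C(c2ccccc2)N1c1ccncc1`: in this assay compound 3 gives 526 nM.

Compound 3 holds the lowest number of the three, beyond the scatter from both others. Compound 4 `N#C/N=C1\N(CCCCCCCOc2ccc(Cl)cc2)C(=O)C(c2ccccc2)N1c1ccncc1` differs from it by (4-chlorophenoxy)methyl in place of 4-chlorophenoxy on a saturated chain carbon, six bonds along the chain from an amide-type nitrogen in a ring. Among the compounds with values here, the one measured step of the same kind is a 6.8-fold lower number from compound 2 to compound 3 (0.83 log units; beyond the scatter), where one added chain carbon brought the number down sharply. Whether a further carbon does so again is not shown: compound 1 carries the longer chain without the phenyl on the ring and gives a high number, but it differs from compound 4 in two places and so gives no clean comparison. The expected step of a 1.1-fold higher number from compound 3 to compound 4 (0.06 log units; within the scatter) is therefore small and uncertain in direction. Compound 4 is estimated at 600 nM, within 150 nM to 2500 nM.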

Compound 4, half-maximal inhibitory concentration: 831 nM
Estimate against measurement, compound 4: 1.4-fold (0.14 log units) below, within the range that was stated.
By their numbers in this assay, from the lowest: compounds 3 and 4 (each within the scatter of the next); then compounds 1 and 2 (each within the scatter of the next).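

In this assay, the further chain carbon does not repeat the earlier sharp drop: the result is a 1.6-fold higher number from compound 3 to compound 4 (0.20 log units; within the scatter). The lower number still holds against the shortest chain with the phenyl in place, at a 4.3-fold lower number from compound 2 to compound 4 (0.64 log units; beyond the scatter), and phenyl in place of hydrogen on the saturated ring carbon can now be read as a single change, at a 4.2-fold lower number from compound 1 to compound 4 (0.62 log units; beyond the scatter). No measurement shown explains either effect.

Still open, as far as these compounds go, is whether a longer chain keeps the number this low. Also open, from the compounds shown here alone, is whether an amine or a carboxylic acid could replace the phenyl on that ring carbon.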